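Swapping an ester for a benzylamide on the shared core

The source may hold more compounds than are shown below. What is called first, only, known or untested is meant among the compounds shown, and "the series" means these compounds.

Of the compounds shown here, three with a shared core have been tested in an ADME assay on HS27 cells (Homo sapiens) for cytotoxicity, read by MTT assay; on this read-out lower numbers stand for stronger inhibition and higher numbers for weaker inhibition. Compound 2 `COC(=O)c1ccc2c(ccn2-c2ccc(NC(=O)c3ccc(Cl)c(C(F)(F)F)c3)cc2)n1` gives 2900 nM, the lowest of the three numbers; compound 1 `O=C(Nc1ccc(-n2ccc3nc(C(=O)NCc4ccccc4)ccc32)cc1)Nc1ccc(Cl)c(C(F)(F)F)c1` gives 3000 nM, which lies within the scatter of compound 2, and compound 3 `COC(=O)c1ccc2c(ccn2-c2ccc(NC(=O)c3cccc(C(F)(F)F)c3)cc2)n1` gives 9800 nM, which lies beyond it. Going by the values given here, the one single-point step among the measured compounds is a 3.4-fold higher number from compound 2 to compound 3 (0.53 log units; beyond the scatter), a hydrogen in place of chloro on an aromatic carbon.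

Compound 4 `O=C(Nc1ccc(-n2ccc3nc(C(=O)NCc4ccccc4)ccc32)cc1)c1ccc(Cl)c(C(F)(F)F)c1` differs from compound 2 by benzylamino in place of methoxy on a carbonyl carbon: the methoxycarbonyl group becomes a benzylcarbamoyl group, so a hydrogen-bond acceptor leaves and a hydrogen-bond donor arrives. Among the compounds with values here, no measured step covers this exchange; the only measured step concerns the chloro on the other end of the molecule and says nothing about the carbonyl side. Compound 1 already carries the benzylcarbamoyl group and differs from compound 2 elsewhere, and its value and that of compound 2 sit within the scatter, which hints that this end of the molecule changes little in this assay.

The step from compound 2 to compound 4 is therefore expected to be a 1.0-fold higher number from compound 2 to compound 4 (0.01 log units; within the scatter), nothing beyond the scatter. Compound 4 is estimated at 3000 nM, within a range from 1400 nM to 6500 nM.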

Compound 4, half-maximal inhibitory concentration: 1500 nM
Compound 4: the middle estimate sits 2.0-fold (0.30 log units) above what was measured; low and high end bracket the measured number.
By their numbers in this assay, from the lowest: compounds 4, 2 and 1 (each within the scatter of the next); then compound 3.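

In this assay, going by these compounds alone, the new result gives the first direct reading at this carbonyl carbon: benzylamino in place of methoxy brings a 1.9-fold lower number from compound 2 to compound 4 (0.29 log units; within the scatter). So exchanging the small methoxy for a much larger group, with a six-membered aromatic ring and a hydrogen-bond donor, gives no step beyond the scatter, which makes this end of the molecule look open to a bulky amide, at least in these compounds. The linker on the other side reads the same way, as 4-chloro-3-(trifluoromethyl)phenyl in place of (4-chloro-3-(trifluoromethyl)phenyl)amino on a carbonyl carbon gives a 2.0-fold lower number from compound 1 to compound 4 (0.30 log units; within the scatter), and no measurement at hand offers an explanation for these numbers.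

The compounds shown leave open how a small methylamino group or a free carboxylic acid on the same carbonyl carbon would read in this assay, and so whether the benzyl ring or the amide hydrogen has any part in the result. Within the data shown here, they also leave open whether removing the chloro, the one change with a step beyond the scatter, would count as much in a compound carrying the benzylcarbamoyl group as it does in one carrying the methoxycarbonyl group.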